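This account rests on a few compounds, and the source may have more. Where it says the series, first, only, none or still open, it means among the compounds named here.

Measured so far in a physicochemical assay for solubility, read by HPLC, using the shake flask method, measured as kinetic solubility, with a stated time of 2 h, at pH 7.4; on this read-out lower numbers stand for lower solubility and higher numbers for higher solubility:
compound 1 `Cc1cc(NCCCc2ccccn2)n2nc(C)c(-c3ccccc3)c2n1` gives 5900 nM
compound 2 `Cc1cc(NCc2cccs2)n2nc(C)c(-c3ccccc3)c2n1` gives only a limit, < 5000 nM
compound 3 `COc1ccc(-c2cnn3c(NCc4ccccn4)cc(C)nc23)cc1` gives only a limit, < 5000 nM

Compound 3 thus stands at the limit rather than at a number; it shares that position with one other compound, as noted in the limit of < 5000 nM in this assay, at which 2 of the 3 values shown sit, and only compound 1 has a numeric value in this assay. For the measured compounds named here, the single measured step, an at least 1.1-fold lower number from compound 1 to compound 2 (0.07 log units; that floor lies within the scatter), concerns a different part of the molecule and its floor lies within the scatter.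

Compound 4 `Cc1cc(NCc2ccccn2)n2ncc(-c3ccc(O)cc3)c2n1` differs from compound 3 by hydrogen in place of methyl on an oxygen on an aromatic ring. Going by the values given here, no measured step covers this change, so nothing in the data fixes its direction or size in this assay. The expectation for compound 4 is therefore anchored on the limit of compound 3, with a wide range and a fair chance that this assay again returns only a limit. Compound 4 is estimated at 5000 nM, between 1500 nM and 20000 nM. The expected step is a number no lower from compound 3 to compound 4 (the limit leaves the size open).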

Compound 4, solubility: 10900 nM
Estimate against measurement, compound 4: 2.2-fold (0.34 log units) below; low and high end bracket the measured number.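

Hydrogen in place of methyl on an oxygen on an aromatic ring gives the first step in this assay that clears the scatter: an at least 2.1-fold higher number from compound 3 to compound 4 (0.33 log units; beyond the scatter). Compound 4 gives a number, 10900 nM, so the 4-hydroxyphenyl end of this pair is fixed. The size of the step remains a floor, because compound 3 holds a limit and not a number: the limit of < 5000 nM in this assay, at which 2 of the 4 values shown sit.

On these data alone, how far the true step lies beyond that floor stays open, as does whether the change from 4-methoxyphenyl to 4-hydroxyphenyl would carry over to the side chains of compound 1 and compound 2. Also open, as far as these compounds go, is whether a carboxylic acid or an amine in place of hydroxy would move the number in the same direction.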